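A few compounds are considered here, and "the series" means these few. Any claim that something is new, unique, unknown or untested is made for them only; others in the source may bear on it.

Measured compounds:
Compound 1 `COc1cc2c(Oc3ccc(NC(=O)c4nccc(-c5ccc(C)cc5)n4)cc3F)ccnc2cc1OCCCN1CCCCC1`, with 580 nM in a functional assay on MKN-45 cells (Homo sapiens) for cytotoxicity, read by MTT assay, with a stated time of 72 h; a lower number here means a stronger inhibitor, a higher number a weaker inhibitor.
Compound 2 `COc1cc2c(Oc3ccc(NC(=O)c4nccc(-c5ccc(C)cc5)n4)cc3F)ccnc2cc1OCCCN1CCN(C)CC1`, with 340 nM in this assay.

In this assay compound 2 gives 340 nM. Compound 2 and compound 1 differ only in the ring at the end of the chain, and a 1.7-fold lower number from compound 1 to compound 2 (0.23 log units; within the scatter), so the two numbers sit together within the scatter and neither can be called stronger.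

Compound 3 `COc1cc2c(Oc3ccc(NC(=O)c4nccc(-c5ccc(F)cc5F)n4)cc3F)ccnc2cc1OCCCN1CCN(C)CC1` has not been measured. It differs from compound 2 at the aryl group attached to the shared core: 2,4-difluorophenyl in place of 4-methylphenyl on an aromatic carbon. Among the measured compounds shown here, no measured step touches this part of the molecule; the one step known, between compound 1 and compound 2, concerns the far end of the chain. The expectation therefore rests on compound 2 alone, and the estimated change for compound 3 is a 1.1-fold lower number from compound 2 to compound 3 (0.05 log units; within the scatter), a step not expected to exceed the scatter. Compound 3 is expected to give about 300 nM in this assay, within a range from 100 nM to 900 nM.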

Compound 3, half-maximal inhibitory concentration: 440 nM
Beside the measured number, compound 3's estimate is 1.5-fold (0.17 log units) below it; the range from low to high includes it.
By their numbers in this assay, from the lowest: compounds 2, 3 and 1 (each within the scatter of the next).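

In this assay, among the compounds shown here, the change to 2,4-difluorophenyl in place of 4-methylphenyl gives a 1.3-fold higher number from compound 2 to compound 3 (0.11 log units; within the scatter) at a part of the molecule that no earlier pair had touched. This aromatic carbon has now been varied once, and the two aryl groups give numbers that sit together, much as the two rings at the far end of the chain do in a 1.7-fold lower number from compound 1 to compound 2 (0.23 log units; within the scatter) in the earlier step. Nothing measured here bears on what lies behind this result.

Going by these compounds, what a 4-methoxyphenyl or a pyridyl ring would give here stays open, as does whether any group at this position can move the number beyond the scatter. On these data alone, the two fluorines also enter as a pair, so the share of each is unknown, and a 4-fluorophenyl group would begin to separate them.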